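The source may report more compounds than this note shows. Statements on the series, on what has been measured and on what is new or still open speak of the compounds shown alone.

Measured compounds:
Compound 1, `Cc1ccc(-c2cnc(Nc3ccc(C#N)cc3)nc2Oc2c(C)cc(C#N)cc2C)cc1`: 26100 nM
Compound 2, `Cc1cc(C#N)cc(C)c1Oc1nc(Nc2ccc(C#N)cc2)ncc1-c1ccoc1`: 4980 nM
Compound 3, `Cc1cc(C#N)cc(C)c1Oc1nc(Nc2ccc(C#N)cc2)ncc1-c1ccc(Cl)cc1`: 72600 nM

All three were tested in an ADME assay on MT4 cells (Homo sapiens) for cytotoxicity, read by MTT assay, with a stated time of 5 days; on this read-out higher numbers stand for lower toxicity in this test and lower numbers for higher toxicity in this test. Compound 3 stands highest of the three, with the nearest number coming from compound 1, as shown by a 2.8-fold higher number from compound 1 to compound 3 (0.44 log units; beyond the scatter), and the furthest from compound 2, as shown by a 15-fold higher number from compound 2 to compound 3 (1.16 log units; beyond the scatter). The remaining step, a 5.2-fold lower number from compound 1 to compound 2 (0.72 log units; beyond the scatter), also concerns the same pendant aryl group.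

Compound 4, `Cc1cc(C#N)cc(C)c1Oc1nc(Nc2ccc(C#N)cc2)ncc1-c1ccc(-c2ccccc2)cc1`, has not been measured. It differs from compound 3 in this way: phenyl in place of chloro on an aromatic carbon.

Among the compounds with values here, all three measured steps concern changes on this pendant aromatic ring, yet none of them puts phenyl in place of chloro, so there is no direct precedent. The changes seen so far on this ring gave modest to large steps, and the pair of steps that involve compound 3 both moved the number upward. Compound 4 is therefore expected to stay within a modest step of compound 3, with direction uncertain, so that a 1.6-fold lower number from compound 3 to compound 4 (0.21 log units; within the scatter) is anticipated. The estimate for compound 4 in this assay is 45000 nM, with a range from 12000 nM to 130000 nM.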

Compound 4, half-maximal cytotoxic concentration: > 253000 nM
Compound 4: a limit, no number; the forecaster's own chance of this, stated with the estimate: 20%; at least 5.6-fold (0.74 log units) between middle value and limit.
By their numbers in this assay, from the lowest: compound 2; then compound 1; then compound 3. At a limit, above all of these: compound 4.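

In this assay compound 4 gives a limit and not a number: the limit of > 253000 nM in this assay, at which 1 of the 4 values shown sits.

Phenyl in place of chloro gives an at least 3.4-fold higher number from compound 3 to compound 4 (0.54 log units; beyond the scatter), so this position, para to a large group, carries a second aromatic ring with no fall in the number, which the earlier compounds could not show. The wider comparisons, an at least 50-fold higher number from compound 2 to compound 4 (1.70 log units; beyond the scatter) and an at least 9.6-fold higher number from compound 1 to compound 4 (0.98 log units; beyond the scatter), show that none of the other three pendant groups reaches the 4-phenylphenyl result.

As far as these compounds go, how far the true value of compound 4 lies past its limit stays open. Also open, from the compounds shown here alone, is whether an amine or a carboxylic acid in place of chloro would keep the number this high.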